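Compound 1 to compound 4: a 6-methylpyridin-2-yl swap

The source may report more compounds than this note shows. Statements on the series, on what has been measured and on what is new or still open speak of the compounds shown alone.

Among the measured compounds shown here, in a functional assay on K562 cells (Homo sapiens) for cytotoxicity, with a stated time of 72 h (a lower number here means a stronger inhibitor, a higher number a weaker inhibitor), compound 1 `CC1c2c(-c3ccncc3)c(-c3ccccc3C#N)nn2CC1(C)C` gives 77000 nM, the only actual number in this small set. Compound 2 `CC1(C)Cc2c(-c3ccncc3)c(-c3ccccn3)nn2C1` reads > 100000 nM, which is a limit. Compound 3 `CCc1cccc(-c2nn3c(c2-c2ccncc2)C(C)C(C)(C)C3)n1` reads > 100000 nM, also a limit. The ceiling here is the limit of > 100000 nM in this assay, at which 2 of the 3 values shown sit. Compound 4 `Cc1cccc(-c2nn3c(c2-c2ccncc2)C(C)C(C)(C)C3)n1` is unmeasured and departs from compound 1 as follows: 6-methylpyridin-2-yl in place of 2-cyanophenyl on an aromatic carbon. For the measured compounds named here, the one measured step bearing on this is an at least 1.2-fold higher number from compound 1 to compound 3 (0.11 log units; that floor lies within the scatter). Compound 3 carries 6-ethylpyridin-2-yl on that carbon, so a small upward shift in this assay, hard to tell from the scatter, is expected. The expected step is a 1.3-fold higher number from compound 1 to compound 4 (0.11 log units; within the scatter). For compound 4 the estimate is 100000 nM, with an expected range of 50000 nM to 200000 nM.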

Compound 4, half-maximal inhibitory concentration: > 100000 nM
Compound 4 ended at the assay's limit; the forecaster's own chance of this, stated with the estimate: 70%; the middle value lies on the limit itself.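

With 6-methylpyridin-2-yl on this aromatic carbon, this assay shows an at least 1.2-fold higher number from compound 1 to compound 4 (0.11 log units; that floor lies within the scatter) and so adds a second replacement of 2-cyanophenyl with no step beyond the scatter. The step between compound 3 and compound 4 cannot be read, as both values are limits. Methyl and ethyl on the pyridin-2-yl ring therefore cannot be told apart, and the series now gathers at the ceiling: the limit of > 100000 nM in this assay, at which 3 of the 4 values shown sit.

From the compounds shown here alone, how far compound 3 and compound 4 lie past that limit remains open. Also open, going by these compounds, is whether an amine or a carboxylic acid on this carbon would give a readable number.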